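Phenyl in Place of Benzylamino: Expecting Compound 4

The compounds below may be only part of what the source reports. "The series", "measured", "known", "first", "only" and "open" are said of these compounds alone.

Compound 1 `CCCCN(CCCC)Cc1cn(CC(O)COC(=O)NCc2ccccc2)nn1` and compound 2 `CCCCN(CCCC)Cc1cn(CC(O)COC(=O)c2ccccc2)nn1` share one core and differ in a single place. In an assay on nucleic acid for inhibition of Nucleic Acid, read by fluorescence, tested at 100 uM (on this read-out lower numbers stand for less inhibition and higher numbers for more inhibition at the one concentration tested (going by the name of the read-out)), compound 1 gives 42%, while compound 2 gives 12%. The change between them is phenyl in place of benzylamino on a carbonyl carbon, and it produced a step of a number 30 percentage points lower from compound 1 to compound 2 (beyond the scatter). Compound 3 `O=C(NCc1ccccc1)OCC(O)Cn1cc(CN2CCN(c3ccccc3)CC2)nn1` also carries a benzylamino group on a carbonyl carbon but sits on another core; in this assay compound 3 gives 32%. The difference between the core of compound 1 and the core of compound 3 is not broken down here. Compound 4 `O=C(OCC(O)Cn1cc(CN2CCN(c3ccccc3)CC2)nn1)c1ccccc1` has not yet been measured; it differs from compound 3 by phenyl in place of benzylamino on a carbonyl carbon, the same change seen between compound 1 and compound 2, at the same place. Because the earlier step was a number 30 percentage points lower from compound 1 to compound 2 (beyond the scatter), compound 4 is expected to fall by a comparable amount, a number 27 percentage points lower from compound 3 to compound 4 (beyond the scatter). Compound 4 is therefore estimated at 5%, most likely between -10% and 25%.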

Compound 4, a percentage reported as inhibition, at one concentration (the size of the read-out at that concentration, not a potency): 11%
For compound 4 the middle estimate is 6 percentage points below the measured one; low and high end bracket the measured number.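

In this assay, putting phenyl in place of benzylamino on the carbonyl carbon on the second core again gives a number 21 percentage points lower from compound 3 to compound 4 (beyond the scatter). Set beside the first case, the change carries over from one core to the other with a similar size: the same change on two cores in this assay, a number 30 percentage points lower (beyond the scatter) from compound 1 to compound 2 and a number 21 percentage points lower (beyond the scatter) from compound 3 to compound 4, 9 percentage points apart, within the scatter of two such steps. Within the data shown here, this rests on only two pairs of compounds, each read at one concentration, so it says nothing about potency and does not show that the change would behave the same way on any further core.

The compounds shown leave open whether a smaller group such as methylamino on the same carbonyl carbon would keep the higher numbers of compound 1 and compound 3. They also leave open what a cyclohexyl group in place of phenyl would give.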